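The source may report more compounds than this note shows. Statements on the series, on what has been measured and on what is new or still open speak of the compounds shown alone.

Compound 2 `CCCN(CCC)c1ccc(C(=O)N2CCc3ccc(OS(N)(=O)=O)cc3C2)cc1` carries a dipropylamino group on the shared core; in an assay on HEK293 cells for inhibition of Steryl-sulfatase (Homo sapiens), tested at 1 uM (a lower number here means a weaker effect, a higher number a stronger effect of the compound at the concentration tested), compound 2 gives 84.7%. Within the data shown here, on the two numbers measured so far compound 2 stands as the lower one, the other being compound 1 `CC(C)CCN(CCC(C)C)c1ccc(C(=O)N2CCc3ccc(OS(N)(=O)=O)cc3C2)cc1`, which in this assay gives 90.8%; the step of a number 6.1 percentage points lower from compound 1 to compound 2 (within the scatter) lies within the scatter, so the two are not ordered. Compound 3 `CCN(Cc1cccc(Br)c1)c1ccc(C(=O)N2CCc3ccc(OS(N)(=O)=O)cc3C2)cc1` differs from compound 2 in one place: (3-bromobenzyl)(ethyl)amino in place of dipropylamino on an aromatic carbon. Among the measured compounds shown here, only the step from compound 1 to compound 2 bears on this change, as it also swaps the groups on the same amine nitrogen, and it was small. For the measured compounds named here, the entering group brings an aromatic ring and a bromine, for which no measured pair gives guidance, so no shift beyond the scatter is expected in this assay. For compound 3 the expected value in this assay is 82%, within 62% to 95%, an expected step of a number 2.7 percentage points lower from compound 2 to compound 3 (within the scatter).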

Compound 3, a percentage reported as inhibition, at one concentration (the size of the read-out at that concentration, not a potency): 97.2%
The estimate for compound 3 lay 15.2 percentage points below the measured number; measured number above the stated range.
By their numbers in this assay, from the lowest: compounds 2, 1 and 3 (each within the scatter of the next, the first and the last beyond it).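

In this assay, among these compounds, the amino group on this aromatic carbon tolerates a substituent bearing an aromatic ring: (3-bromobenzyl)(ethyl)amino in place of dipropylamino gives a number 12.5 percentage points higher from compound 2 to compound 3 (beyond the scatter) and is the first step beyond the scatter. The same entering group in place of diisopentylamino gives a number 6.4 percentage points higher from compound 1 to compound 3 (within the scatter) and leaves compound 1 and compound 3 unordered, so the rise holds against dipropylamino only. Nothing measured on these compounds accounts for the step.

As far as these compounds go, compound 3 changes the benzyl ring, the bromine and the ethyl group together, so the share of each in the step remains open. Also open, from the compounds shown here alone, is how this position would read with a plain benzyl group, a chlorine in place of the bromine, or a carboxylic acid on the chain.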